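Bromo for iodo in a close-lying series

The source may report more compounds than this note shows. Statements on the series, on what has been measured and on what is new or still open speak of the compounds shown alone.

Of the compounds shown here, three sharing one core have been read in an ADME assay on MT4 cells (Homo sapiens) for cytotoxicity, read by XTT assay, with a stated time of 3 days (on this read-out lower numbers stand for higher toxicity in this test and higher numbers for lower toxicity in this test), and they sit close together. Compound 1 `CCOCn1c(Cc2cc(C)cc(C)c2)c(I)c(=O)[nH]c1=O` gives 142000 nM in this test, compound 2 `Cc1cc(C)cc(Cc2c(I)c(=O)[nH]c(=O)n2COCc2ccccc2)c1` gives 98300 nM here, and compound 3 `O=c1[nH]c(=O)n(COCc2ccccc2)c(Cc2cc(F)cc(F)c2)c1I` gives 121000 nM on the same read-out. Compound 2 therefore holds no separate place, since its value lies within the scatter of the other two.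

Compound 4 `Cc1cc(C)cc(Cc2c(Br)c(=O)[nH]c(=O)n2COCc2ccccc2)c1` carries bromo in place of iodo on an aromatic carbon and is otherwise the same as compound 2. Two measured steps lie elsewhere in the structure. The step of a 1.4-fold lower number from compound 1 to compound 2 (0.16 log units; within the scatter) came with phenyl in place of methyl, and the step of a 1.2-fold higher number from compound 2 to compound 3 (0.09 log units; within the scatter) came with 3,5-difluorophenyl in place of 3,5-dimethylphenyl. Neither exchange touches the halogen, so they bear on this change only indirectly, as a sign of how little the numbers in this assay have moved so far.

Starting from compound 2 at 98300 nM and those two small steps, no shift beyond the scatter is expected, and no direction can be named. The estimated step of a 1.1-fold higher number from compound 2 to compound 4 (0.05 log units; within the scatter) is accordingly small. For compound 4 the expected value is 110000 nM with an estimated range from 55000 nM to 220000 nM as the likely span.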

Compound 4, half-maximal cytotoxic concentration: 152000 nM
Beside the measured number, compound 4's estimate is 1.4-fold (0.14 log units) below it; the measured number falls inside the stated range.
By their numbers in this assay, from the lowest: compounds 2, 3, 1 and 4 (each within the scatter of the next).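

The halogen on the aromatic carbon, ortho to a 3,5-dimethylbenzyl group, is the third place in this series where a change has been read, and bromo in place of iodo gives a 1.5-fold higher number from compound 2 to compound 4 (0.19 log units; within the scatter) in this assay. This position therefore behaves like the two read earlier: on this one pair, the exchange of one halogen for the other leaves compound 2 and compound 4 within the scatter of each other, so neither can be placed ahead of the other in this test. Nothing available bears on why the read-out stays so flat at this position.

The compounds shown leave open whether a group of a different kind on this carbon, such as an amine, a nitrile or a methyl group, would move the number beyond the scatter. They also leave open whether bromo in place of iodo would read the same with the 3,5-difluorophenyl group of compound 3 or the shorter ethoxymethyl chain of compound 1 in the molecule.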